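The source may hold more compounds than are shown below. What is called first, only, known or untested is meant among the compounds shown, and "the series" means these compounds.

In a functional assay on RS4-11 cells (Homo sapiens) for inhibition, read by CCK-8 assay, with a stated time of 48 h, tested at 20 uM (on this read-out higher numbers stand for more inhibition of growth at the one concentration tested and lower numbers for less inhibition of growth), compound 3 (`COc1ccc(S(=O)(=O)Oc2ccccc2/C=C(\C#N)C(=O)Nc2nnc(Cc3ccc(C)cc3)s2)cc1`) gives 79% and stands highest of the three measured compounds, ahead of compound 1 (`COc1ccc(Cc2nnc(NC(=O)/C(C#N)=C/c3ccccc3OS(=O)(=O)c3ccccc3[N+](=O)[O-])s2)cc1`) with 68% and compound 2 (`N#C/C(=C\c1ccccc1OS(=O)(=O)c1ccccc1[N+](=O)[O-])C(=O)Nc1nnc(Cc2ccc(F)cc2)s1`) with 61% on the same read-out. Compound 4 (`Cc1ccc(Cc2nnc(NC(=O)/C(C#N)=C/c3ccccc3OS(=O)(=O)c3ccccc3[N+](=O)[O-])s2)cc1`) departs from compound 3 at one place, on a sulfonyl sulfur: 2-nitrophenyl in place of 4-methoxyphenyl on a sulfonyl sulfur is the whole change. Within the data shown here, the only measured single-place step is a number 7 percentage points lower from compound 1 to compound 2 (within the scatter) and it sits on an aromatic carbon, so no measured step tests this exchange directly. The expectation rests instead on compound 1 at 68% and compound 2 at 61% as both carry 2-nitrophenyl on the sulfonyl sulfur, as compound 4 does. Both also differ from compound 3 elsewhere, so this evidence is indirect. The expected step in this assay is a number 12 percentage points lower from compound 3 to compound 4 (beyond the scatter) and its expected direction is downward. Compound 4 is estimated at 67% (expected range 55% to 79%).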

Compound 4, percent growth inhibition at one concentration: "not active" (no number reported)
The entry for compound 4 holds no number; no gap can be computed for the estimate.
By their numbers in this assay, from the lowest: compounds 2 and 1 (each within the scatter of the next); then compound 3.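

In this assay, among these compounds, compound 4 is recorded as not active with no number, so no step from compound 3 to compound 4 can be read. No other measurement bears on this result. What the exchange of 4-methoxyphenyl for 2-nitrophenyl on a sulfonyl sulfur does to growth inhibition stays open in the compounds shown.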